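The compounds below may be only part of what the source reports. "The series", "measured", "known", "first", "only" and "open" are said of these compounds alone.

Compound 3 `CC(=O)N1CCC(NS(=O)(=O)c2ccc(NC(=O)c3ccccc3C)c3ccccc23)CC1` stands second highest of the three numbers recorded in an assay on L1.2 cells for binding affinity to C-C chemokine receptor type 8 (Homo sapiens); on this read-out lower numbers stand for stronger inhibition and higher numbers for weaker inhibition: compound 3 gives 6.7 nM, compound 2 `CCOC(=O)N1CCC(NS(=O)(=O)c2ccc(NCCCc3ccccc3)c3ccccc23)CC1` gives 32.1 nM, and compound 1 `CCOC(=O)N1CCC(NS(=O)(=O)c2ccc(NC(=O)c3ccccc3)c3ccccc23)CC1` gives 0.17 nM. Compound 1 and compound 3 differ in two places at once, so their values are only set side by side. Among the compounds with values here, the one single step measured is the change on the aryl amide nitrogen, a 190-fold higher number from compound 1 to compound 2 (2.28 log units; beyond the scatter), which concerns a different part of the molecule.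

Compound 4 `Cc1ccccc1C(=O)Nc1ccc(S(=O)(=O)NC2CCN(C(=O)CCN)CC2)c2ccccc12` differs from compound 3 by aminomethyl in place of hydrogen on a saturated chain carbon bound to a carbonyl carbon. Within the data shown here, no measured step touches this carbonyl substituent, and the aryl amide of compound 3 is kept unchanged in compound 4, so the single large step from compound 1 to compound 2 gives no guidance here. With nothing to go on, the expected step of a 1.3-fold lower number from compound 3 to compound 4 (0.13 log units; within the scatter) is small and may well lie within the scatter. Compound 4 is therefore estimated at 5 nM in this assay, with a range from 1.2 nM to 25 nM.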

Compound 4, inhibition constant: 11.3 nM
Beside the measured number, compound 4's estimate is 2.3-fold (0.35 log units) below it, within the range that was stated.
By their numbers in this assay, from the lowest: compound 1; then compounds 3 and 4 (each within the scatter of the next); then compound 2.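

In this assay, within the data shown here, the first measured step at this carbonyl substituent, aminomethyl in place of hydrogen on a saturated chain carbon bound to a carbonyl carbon, is a 1.7-fold higher number from compound 3 to compound 4 (0.23 log units; within the scatter). Acetyl and (2-aminoethyl)carbonyl therefore cannot be told apart here, even though the entering group adds 2 heavy atoms, 1 hydrogen-bond donor and 1 hydrogen-bond acceptor, whereas the change on the aryl amide nitrogen gave a 190-fold higher number from compound 1 to compound 2 (2.28 log units; beyond the scatter). No available evidence bears on this result.

As far as these compounds go, whether a longer chain, a dimethylamino group or a carboxylic acid at this chain carbon would also stay within the scatter remains open. From the compounds shown here alone, this single step also rests on the amide of compound 3, so it remains open whether the same change would read alike with the benzoyl amide of compound 1.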